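A few compounds are considered here, and "the series" means these few. Any claim that something is new, unique, unknown or untested is made for them only; others in the source may bear on it.

Of the compounds shown here, three sharing one core have been tested in a functional assay on PBMC cells (Homo sapiens) for inhibition, read by ELISA, with a stated time of 18 h; on this read-out lower numbers stand for stronger inhibition and higher numbers for weaker inhibition. Compound 1 `CC1(C)CC(=O)C=C(Nc2ccc(Cl)cc2)C1` carries the bare core. In this assay compound 1 gives > 20 ug/mL, which is a limit of the assay rather than a number. Compound 2 `CCCCCCCCCCCSC(=S)C1=C(Nc2ccc(Cl)cc2)CC(C)(C)CC1=O` adds a decyl chain through a sulfur. In this assay compound 2 gives > 20 ug/mL, again only a limit. Compound 3 `CC1(C)CC(=O)C(C(=S)SCc2ccccc2)=C(Nc2ccc(Cl)cc2)C1` carries a benzyl group in place of that chain. In this assay compound 3 gives > 20 ug/mL, also a limit. Compound 3 therefore stands where every measured compound stands, at the limit of > 20 ug/mL in this assay, at which 3 of the 3 values shown sit. The step that the two limits leave unreadable from compound 2 to compound 3 cannot be read, since both of its ends are limits. Compound 4 `CC1(C)CC(=O)C(C(=S)SCCO)=C(Nc2ccc(Cl)cc2)C1` differs from compound 3 by hydroxymethyl in place of phenyl on a saturated chain carbon bound to a sulfur. Going by the values given here, no measured step bears on this change, as every value gathered so far is a limit and none of the three structural variations has moved a compound off it. The step that the limit leaves unreadable from compound 3 to compound 4 is therefore expected to stay within the scatter, with no value beneath the limit foreseen. Compound 4 is expected to give about 30 ug/mL in this assay, within a range from 8 ug/mL to 100 ug/mL.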

Compound 4, half-maximal inhibitory concentration: > 20 ug/mL
Compound 4 ended at the assay's limit; the forecaster's own chance of this, stated with the estimate: 85%; the middle value is on the limit's open side.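

In this assay compound 4 gives > 20 ug/mL, which is a limit and not a number, so its steps from compound 1, compound 2 and compound 3 cannot be read. The compounds shown leave open which change to the shared core, if any, would give a measurable value, as all of them rest at one limit: the limit of > 20 ug/mL in this assay, at which 4 of the 4 values shown sit.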